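Chloro to bromo in a weakly inhibiting series

A few compounds are considered here, and "the series" means these few. Any claim that something is new, unique, unknown or untested is made for them only; others in the source may bear on it.

In a functional assay on KB cells (Homo sapiens) for inhibition (on this read-out lower numbers stand for stronger inhibition and higher numbers for weaker inhibition), compound 1 `Cc1cccc(Cn2c(Cl)nc3cc(Cl)c(Cl)cc32)c1` gives > 100000 nM as a limit of the assay, not a number. Compound 2 `FC(F)(F)c1cccc(Cn2c(Cl)nc3cc(Cl)c(Cl)cc32)c1` gives > 100000 nM as a limit too. Going by the values given here, compound 3 `O=[N+]([O-])c1cccc(Cn2c(Cl)nc3cc(Cl)c(Cl)cc32)c1` gives 239000 nM and holds the only actual number here. Compound 4 `O=[N+]([O-])c1cccc(Cn2c(Br)nc3cc(Cl)c(Cl)cc32)c1` has one change from compound 3: bromo in place of chloro on an aromatic carbon with bromo in place of chloro on an aromatic carbon, between two ring nitrogen atoms. The measured steps, a step that the limit leaves unreadable from compound 1 to compound 3 and a step that the limit leaves unreadable from compound 2 to compound 3 as they stand, concern a different group and offer no size to carry over. No step beyond the scatter is therefore expected, and the estimate is a 1.2-fold lower number from compound 3 to compound 4 (0.08 log units; within the scatter) in size. Compound 4 is expected at 200000 nM with a range of 70000 nM to 450000 nM as the estimate.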

Compound 4, half-maximal inhibitory concentration: 150000 nM
Estimate against measurement, compound 4: 1.3-fold (0.12 log units) above; measured number inside the range.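

Bromo in place of chloro on the aromatic carbon between two ring nitrogen atoms gives a 1.6-fold lower number from compound 3 to compound 4 (0.20 log units; within the scatter), so this assay does not separate the two halogens at this position while the nitro group stays in place. This is the only step in the set with a readable size, since the other steps, among compound 1, compound 2 and compound 3, cannot be read: the limit of > 100000 nM in this assay, at which 2 of the 4 values shown sit.

As far as these compounds go, whether an amine or a methoxy group on the same carbon would shift the number beyond the scatter stays open. So does whether bromo would behave the same way alongside the methyl of compound 1 or the trifluoromethyl of compound 2.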